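Swapping 4-acetylpiperidin-1-yl for chloro on compound 2

The source may report more compounds than this note shows. Statements on the series, on what has been measured and on what is new or still open speak of the compounds shown alone.

For the measured compounds named here, in a functional assay on MGC-803 cells (Homo sapiens) for cytotoxicity, read by MTT assay, with a stated time of 48 h (a lower number here means a stronger inhibitor, a higher number a weaker inhibitor), compound 2 `CC(=O)Oc1ccccc1C1CC(C)=NN1C(=O)CN1CCC(C(C)=O)CC1` gives 4120 nM as the lower of the two numbers so far, and compound 1 `CCN(CC)CC(=O)N1N=C(C)CC1c1ccccc1OC(C)=O` gives 29500 nM as the higher one. Compound 3 `CC(=O)Oc1ccccc1C1CC(C)=NN1C(=O)CCl` differs from compound 2 by the change (chloro in place of 4-acetylpiperidin-1-yl on a saturated chain carbon bound to a carbonyl carbon). That change puts chloro in place of 4-acetylpiperidin-1-yl on a saturated chain carbon bound to a carbonyl carbon. Going by the values given here, the only measured step at this place is a 7.2-fold lower number from compound 1 to compound 2 (0.85 log units; beyond the scatter) and it was modest. Chloro has no measured precedent there, so a similarly modest move toward a higher number is expected, namely a 2.4-fold higher number from compound 2 to compound 3 (0.39 log units; beyond the scatter) as an estimate. Compound 3 is estimated at 10000 nM with an expected range from 2500 nM to 35000 nM for now.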

Compound 3, half-maximal inhibitory concentration: 3010 nM
Compound 3: middle estimate off by 3.3-fold (0.52 log units), on the high side; the measured number falls inside the stated range.
By their numbers in this assay, from the lowest: compounds 3 and 2 (each within the scatter of the next); then compound 1.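

In this assay, chloro in place of 4-acetylpiperidin-1-yl gives a 1.4-fold lower number from compound 2 to compound 3 (0.14 log units; within the scatter), so a single atom matches the whole ring with its acetyl at this saturated chain carbon. Chloro in place of diethylamino gives a 9.8-fold lower number from compound 1 to compound 3 (0.99 log units; beyond the scatter), which leaves compound 1 as the only one of the three set apart by its number. Nothing available here explains either step.

Still open, going by these compounds, is how a carboxylic acid, a simple primary amine or a longer carbon chain would fare at this place.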